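A few compounds are considered here, and "the series" means these few. Any claim that something is new, unique, unknown or untested is made for them only; others in the source may bear on it.

Compound 3 `COC(=O)CC[C@@H](NC(=O)Cn1cc(C2=C(c3c[nH]c4ccccc34)C(=O)N(C)C2=O)c2ccccc21)C(=O)OC` is one of three measured analogues that share a common core and differ only in the amino-acid ester carried on the amide. In a functional assay on HCT-8 cells (Homo sapiens) for cytotoxicity, read by MTT assay, with a stated time of 24 h (a higher number here means a weaker inhibitor, a lower number a stronger inhibitor), compound 3 gives 29200 nM. Compound 2 `COC(=O)[C@H](NC(=O)Cn1cc(C2=C(c3c[nH]c4ccccc34)C(=O)N(C)C2=O)c2ccccc21)C(C)C` gives 25800 nM in this assay, and the pair is separated only by a 1.1-fold higher number from compound 2 to compound 3 (0.05 log units; within the scatter). Compound 1 `CC[C@H](C)[C@@H](NC(=O)Cn1cc(C2=C(c3c[nH]c4ccccc34)C(=O)N(C)C2=O)c2ccccc21)C(=O)OC` reaches only a limit in this assay, > 100000 nM. Among the two values that are numbers, compound 3 thus has the higher one, but its nearest neighbour, compound 2, sits within the scatter, and the one further value is a limit (the limit of > 100000 nM in this assay, at which 1 of the 3 values shown sits).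

The unmeasured compound 4 `COC(=O)[C@@H](CC(C)C)NC(=O)Cn1cc(C2=C(c3c[nH]c4ccccc34)C(=O)N(C)C2=O)c2ccccc21` differs from compound 3 by isopropyl in place of (methoxycarbonyl)methyl on a saturated chain carbon, two bonds along the chain from an amide-type nitrogen and a carbonyl carbon. For the measured compounds named here, two measured steps bear on this. The step of a 1.1-fold higher number from compound 2 to compound 3 (0.05 log units; within the scatter) exchanges an ester chain for a branched alkyl group on the carbon bound to the amide-type nitrogen and shows nothing beyond the scatter. The step of an at least 3.8-fold lower number from compound 1 to compound 2 (0.58 log units; beyond the scatter) shows that removing a methyl from such a branched group lowered the number from a limit. Compound 4 again carries a branched alkyl in place of an ester chain, cut one bond further out, so a modest rise is expected. The step is expected to be a 1.5-fold higher number from compound 3 to compound 4 (0.19 log units; within the scatter). Compound 4 is therefore estimated at 45000 nM, within a range from 15000 nM to 150000 nM.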

Compound 4, half-maximal inhibitory concentration: 37800 nM
Compound 4: middle estimate off by 1.2-fold (0.08 log units), on the high side; the range from low to high includes it.
By their numbers in this assay, from the lowest: compounds 2, 3 and 4 (each within the scatter of the next). At a limit, above all of these: compound 1.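

In this assay, replacing (methoxycarbonyl)methyl with isopropyl on a saturated chain carbon, two bonds along the chain from an amide-type nitrogen and a carbonyl carbon, gives a 1.3-fold higher number from compound 3 to compound 4 (0.11 log units; within the scatter), so removing the ester from this side chain has no effect that can be resolved. The two alkyl side chains also stay together, with isobutyl in place of isopropyl giving a 1.5-fold higher number from compound 2 to compound 4 (0.17 log units; within the scatter), which places compound 2, compound 3 and compound 4 in one group, whether the side chain is branched at the first carbon, branched further out or ends in an ester. Only sec-butyl stands apart, with isobutyl in its place giving an at least 2.6-fold lower number from compound 1 to compound 4 (0.42 log units; beyond the scatter), although the value of compound 1 is a limit and sets only the minimum size of that step: the limit of > 100000 nM in this assay, at which 1 of the 4 values shown sits.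

The compounds shown leave open what a free carboxylic acid, an amine or a phenyl ring on this side chain would do, since all four carry only alkyl or ester side chains. They also leave open the true size of the gap to compound 1, which has no exact number.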